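Cytotoxicity limits across the shared core: fluoro replacing isopropoxy

The source may report more compounds than this note shows. Statements on the series, on what has been measured and on what is new or still open speak of the compounds shown alone.

Three analogues on one shared core have been run in an ADME assay on HEp-2 cells (Homo sapiens) for cytotoxicity, read by MTT assay, with a stated time of 72 h; a higher number here means a weaker inhibitor, a lower number a stronger inhibitor. Compound 1 `C=CCOc1cc(C2=C(c3cc(OC)c(OC)c(OC)c3)C(=O)C(O)C2)ccc1OC` carries an allyloxy group; in this assay compound 1 reaches only the limit > 100 ug/mL, a limit and not a number. Compound 2 `COc1ccc(C2=C(c3cc(OC)c(OC)c(OC)c3)C(=O)C(O)C2)cc1NC(=O)c1ccccc1` carries a benzamido group; compound 2 likewise reaches only the limit > 100 ug/mL. Compound 3 `COc1ccc(C2=C(c3cc(OC)c(OC)c(OC)c3)C(=O)C(O)C2)cc1OC(C)C` carries an isopropoxy group; compound 3 stands at the limit > 100 ug/mL, again a limit rather than a number, so it cannot be ranked against the other two. The three measured steps, a step that the two limits leave unreadable from compound 1 to compound 2, a step that the two limits leave unreadable from compound 1 to compound 3 and a step that the two limits leave unreadable from compound 2 to compound 3, are unreadable because of the limit of > 100 ug/mL in this assay, at which 3 of the 3 values shown sit.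

Compound 4 `COc1ccc(C2=C(c3cc(OC)c(OC)c(OC)c3)C(=O)C(O)C2)cc1F` has not yet been measured. It differs from compound 3 in one place: fluoro in place of isopropoxy on an aromatic carbon. Within the data shown here, none of the measured steps bears readably on this change, as each of them joins two limits; none of them moved a value off the limit. No step beyond the scatter in this assay is therefore expected. Compound 4 is expected to give 150 ug/mL, within 60 ug/mL to 400 ug/mL. The step that the limit leaves unreadable from compound 3 to compound 4 is expected to lie within the scatter, most likely as a further limit.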

Compound 4, half-maximal inhibitory concentration: < 1 ug/mL
Compound 4: no number, only a limit (the forecaster's own chance of this, stated with the estimate: 80%); middle value at least 150-fold (2.17 log units) away from the limit.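

In this assay, the position ortho to a methoxy group and meta to a large group is not indifferent to what it carries: fluoro in place of isopropoxy gives an at least 100-fold lower number from compound 3 to compound 4 (2.00 log units; beyond the scatter), and the same holds against the two other groups, with an at least 100-fold lower number from compound 2 to compound 4 (2.00 log units; beyond the scatter) and an at least 100-fold lower number from compound 1 to compound 4 (2.00 log units; beyond the scatter). The steps among compound 1, compound 2 and compound 3 cannot be read, so allyloxy, benzamido and isopropoxy gave no sign of this sensitivity, as all three compounds rest at one limit: the limit of > 100 ug/mL in this assay, at which 3 of the 4 values shown sit. Compound 4 gives < 1 ug/mL, itself a limit and not a number, so the steps to it fix only a minimum size and not a true one: the limit of < 1 ug/mL in this assay, at which 1 of the 4 values shown sits.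

From the compounds shown here alone, it remains open whether fluoro is singular here or whether any small group would do the same, and a chloro group, a hydroxy group or a plain hydrogen at this position would separate those two readings. A methoxy group or an amine in the same place would also show where, between fluoro and isopropoxy, the read-out leaves the upper limit, and a number for compound 4 would be needed to rank any of them against it.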